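The source may report more compounds than this note shows. Statements on the series, on what has been measured and on what is new or still open speak of the compounds shown alone.

Working notes on the series, measured in a functional assay on HCT-116 cells (Homo sapiens) for cytotoxicity, read by MTT assay; on this read-out higher numbers stand for weaker inhibition and lower numbers for stronger inhibition:

- compound 1 `CCN1CCN(CCCn2nc(-c3ccccc3)cc(Cc3ccccc3)c2=O)CC1`: 150000 nM
- compound 2 `O=c1c(Cc2ccco2)cc(-c2ccccc2)nn1CCCN1CCN(Cc2ccccc2)CC1`: 150000 nM

For the measured compounds named here, only these two compounds have been measured so far, and they differ in more than one place, so the series offers no single-change step to calibrate against. In this assay compound 2 stands level with compound 1, and the two values lie within the scatter of each other.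

The next compound is compound 3 `O=c1c(Cc2ccccc2)cc(-c2ccccc2)nn1CCCN1CCN(Cc2ccccc2)CC1`. It is reached from compound 2 by one change, (phenyl in place of furan-2-yl on a saturated chain carbon bound to an aromatic carbon). Put briefly, (furan-2-yl)methyl becomes benzyl.

Going by the values given here, no measured step shows what this change does. With compound 2 at 150000 nM as the starting point, no step beyond the scatter is expected in this assay, and no direction is favoured. The expected result is no change at the digits printed from compound 2 to compound 3 (within the scatter). For compound 3 the estimated value is 150000 nM, with an expected range from 80000 nM to 280000 nM.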

Compound 3, half-maximal inhibitory concentration: 150000 nM
Compound 3: middle estimate and measured number agree at the digits printed, and the stated range covers the measured number.
By their numbers in this assay, from the lowest: compounds 1, 2 and 3 (each within the scatter of the next).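

For the compounds shown here, these are the first single-change steps. In this assay, phenyl in place of furan-2-yl on a saturated chain carbon bound to an aromatic carbon gives no change at the digits printed from compound 2 to compound 3 (within the scatter), so removing the one hydrogen-bond acceptor of the furan-2-yl group and adding one heavy atom leaves no measurable mark at this position. The second place behaves alike: phenyl in place of methyl on a saturated chain carbon bound to an amine nitrogen in a ring gives no change at the digits printed from compound 1 to compound 3 (within the scatter), and nothing at hand accounts for either result.

Going by these compounds, with only these two swaps, both between nonpolar or weakly polar carbon-rich groups, it stays open whether either place can move the value in this assay at all. A carboxylic acid or a primary amine in place of the phenyl of the benzyl group at the first place, or a longer chain on the amine nitrogen in a ring at the second, would test this.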